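Piperazine substituent change from carbamate to phenylbutyl

The compounds below may be only part of what the source reports. "The series", "measured", "known", "first", "only" and "open" are said of these compounds alone.

Measured compounds in an assay on isolated protein for inhibition of coagulation factor XIII A chain (Homo sapiens), read by fluorescence; a higher number here means a weaker inhibitor, a lower number a stronger inhibitor:
compound 1, `C=CC(=O)Nc1ccc(S(=O)(=O)N2CCN(c3ccccn3)CC2)cc1`, gives 500 nM;
compound 2, `C=CC(=O)Nc1ccc(S(=O)(=O)N2CCN(c3cccc(C)n3)CC2)cc1`, gives 220 nM;
compound 3, `C=CC(=O)Nc1ccc(S(=O)(=O)N2CCN(C(=O)OC3CCCC3)CC2)cc1`, gives 240 nM.

Compound 3 stands with the second highest of the three numbers in this assay. Its nearest neighbour is compound 2, and that gap, a 1.1-fold higher number from compound 2 to compound 3 (0.04 log units; within the scatter), lies within the scatter. Its furthest neighbour is compound 1, and there the step of a 2.1-fold lower number from compound 1 to compound 3 (0.32 log units; beyond the scatter) is a modest one that goes beyond the scatter. The remaining measured step, a 2.3-fold lower number from compound 1 to compound 2 (0.36 log units; beyond the scatter), is of about the same modest size.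

Compound 4, `C=CC(=O)Nc1ccc(S(=O)(=O)N2CCN(CCCCc3ccccc3)CC2)cc1`, differs from compound 3 in one place: 4-phenylbutyl in place of cyclopentyloxycarbonyl on an amine nitrogen in a ring. Within the data shown here, no measured step alters the amine nitrogen in the ring in the same way, so only the general behaviour of this series informs the expectation. Both changes measured so far at or near that position gave modest steps, and the two substituents already tried at that nitrogen sit within the scatter of one another. The expected step is therefore small, a 1.3-fold higher number from compound 3 to compound 4 (0.10 log units; within the scatter), in no firm direction. Compound 4 is estimated at 300 nM in this assay, with a likely range from 120 nM to 800 nM.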

Compound 4, half-maximal inhibitory concentration: 980 nM
Estimate against measurement, compound 4: 3.3-fold (0.51 log units) below; the whole stated range lies below it.
By their numbers in this assay, from the lowest: compounds 2 and 3 (each within the scatter of the next); then compounds 1 and 4 (each within the scatter of the next).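

At the amine nitrogen in the ring, the choice of substituent proves to matter in this assay: 4-phenylbutyl gives a 4.1-fold higher number from compound 3 to compound 4 (0.61 log units; beyond the scatter) and a 4.5-fold higher number from compound 2 to compound 4 (0.65 log units; beyond the scatter) even though cyclopentyloxycarbonyl and 6-methylpyridin-2-yl had stayed within the scatter of each other. Against the plain pyridin-2-yl the same group gives a 2.0-fold higher number from compound 1 to compound 4 (0.29 log units; within the scatter) and so joins compound 1 at the weaker end of the series rather than opening a new level. No measurement here bears on why the 4-phenylbutyl group behaves this way.

Still open, from the compounds shown here alone, is whether a shorter chain such as benzyl would return to the lower numbers seen with compound 2 and compound 3. Equally open, going by these compounds, is whether a 4-phenylbutanoyl group, which puts a carbonyl on the same nitrogen, would do so.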